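A few compounds are considered here, and "the series" means these few. Any claim that something is new, unique, unknown or untested is made for them only; others in the source may bear on it.

Measured compounds in a physicochemical assay for lipophilicity; a higher number here means a more lipophilic compound, a lower number a more polar compound:
- compound 1, `CC(C)Sc1nnc(-c2c(CNC3CC3)c3ccccc3n2C)n1-c1ccccc1`, gives 4.81
- compound 2, `CC(C)Sc1nnc(-c2c(CN3CCCCC3C)c3ccccc3n2C)n1-c1ccccc1`, gives 5.95
- compound 3, `COc1cccc(CNCc2c(-c3nnc(SC(C)C)n3-c3ccccc3)n(C)c3ccc(F)cc23)c1`, gives 6.42

Among these three, compound 3 stands highest in this assay: its number lies above that of compound 2 and further above that of compound 1, both gaps beyond the scatter. Among the measured compounds shown here, the one step recorded between two measured compounds that differ in a single place is a number 1.14 log units higher from compound 1 to compound 2 (beyond the scatter), where a larger saturated ring amine replaced a small one.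

Compound 4, `COc1cccc(CNCc2c(-c3nnc(SC(C)C)n3-c3ccccc3)n(C)c3ccccc23)c1`, is compound 3 with one change: hydrogen in place of fluoro on an aromatic carbon. This is a small exchange, a single halogen atom giving way to a hydrogen atom. The recorded step from compound 1 to compound 2 concerns a quite different part of the molecule, an amine on a saturated chain carbon, and so gives no direct guide to a fluoro-for-hydrogen swap on an aromatic ring. With nothing measured that bears on this change, the expectation rests on its smallness: a step in this assay that stays within the scatter, at most slightly downward, is expected. For compound 4 the estimate is 6.25, with a range from 5.9 to 6.6, which would mean an expected step of a number 0.17 log units lower from compound 3 to compound 4 (within the scatter).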

Compound 4, partition coefficient: 6.27
Compound 4: middle estimate off by 0.02 log units, on the low side, and the stated range covers the measured number.
By their numbers in this assay, from the lowest: compound 1; then compound 2; then compounds 4 and 3 (each within the scatter of the next).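

In this assay, hydrogen in place of fluoro on this aromatic carbon gives a number 0.15 log units lower from compound 3 to compound 4 (within the scatter) and so the two compounds cannot be told apart at this place on the ring. Compound 4 also links this series to the amine changes: (3-methoxybenzyl)amino in place of 2-methylpiperidin-1-yl gives a number 0.32 log units higher from compound 2 to compound 4 (beyond the scatter) and 3-methoxybenzyl in place of cyclopropyl on an amine nitrogen gives a number 1.46 log units higher from compound 1 to compound 4 (beyond the scatter) and both of these steps, unlike the fluoro exchange, lie beyond the scatter. No measurement here explains any of these steps. Still open, going by these compounds, is whether chloro, methoxy or a carboxylic acid on the same aromatic carbon would also stay within the scatter of compound 4. Also open, on these data alone, is whether the fluoro exchange would read the same with a different amine on the chain.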